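The source may report more compounds than this note shows. Statements on the series, on what has been measured and on what is new or still open speak of the compounds shown alone.

Working notes on the series. Compound 3 `COc1cc(OC)cc(-c2cc3ccccc3c(-c3cccc(O)c3)n2)c1` has the lowest of the two numbers shown in a functional assay on DU-145 cells (Homo sapiens) for cytotoxicity, read by CCK-8 assay and cell counting, with a stated time of 72 h; a higher number here means a weaker inhibitor, a lower number a stronger inhibitor: compound 3 gives 3870 nM. Compound 1 `COc1ccc(-c2cc3ccccc3c(-c3cccc(N)c3)n2)cc1` gives 8610 nM. Compound 2 `COc1ccc(-c2cc3ccccc3c(-c3ccc(O)cc3)n2)cc1` gives > 50000 nM, which is a limit of the assay and not a number. Compound 4 `COc1cc(OC)cc(-c2cc3ccccc3c(-c3cccc(N)c3)n2)c1` differs from compound 3 in one place, (amino in place of hydroxy on an aromatic carbon). Among the compounds with values here, the only measured step that touches hydroxy against amino is an at least 5.8-fold higher number from compound 1 to compound 2 (0.76 log units; beyond the scatter), and it also moves the group to another position on that ring, so it bears on the present change only loosely; that step ran toward a higher number when hydroxy replaced amino, and one of its ends is a limit (the limit of > 50000 nM in this assay, at which 1 of the 3 values shown sits). Read the other way, amino in place of hydroxy would point to a lower number, but with the position also shifted the size is uncertain. For compound 4 the expected step is a 1.5-fold lower number from compound 3 to compound 4 (0.19 log units; within the scatter), a modest move to a lower number. Compound 4 is therefore estimated at 2500 nM, with a range from 900 nM to 8000 nM.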

Compound 4, half-maximal inhibitory concentration: 13200 nM
The estimate for compound 4 lay 5.3-fold (0.72 log units) below the measured number; measured number above the stated range.
By their numbers in this assay, from the lowest: compound 3; then compounds 1 and 4 (each within the scatter of the next). At a limit, above all of these: compound 2.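

Within this assay, the change from 3-hydroxyphenyl to 3-aminophenyl on the core of compound 3 gives a 3.4-fold higher number from compound 3 to compound 4 (0.53 log units; beyond the scatter), so at this place, with nothing else altered, hydroxy gives the lower number. The earlier at least 5.8-fold higher number from compound 1 to compound 2 (0.76 log units; beyond the scatter) changed the group and its ring position together and ends at a limit of the assay, so it could not separate the two, and its direction does not carry over to the group swap alone. Nothing shown here accounts for the size or direction of the new step.

From the compounds shown here alone, whether hydroxy also gives the lower number than amino on the core of compound 1 remains open. Also open, going by these compounds, is how a carboxylic acid, an amide or a methoxy group would read at this same place on the ring.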